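Three cinnamate esters and a fourth with a chloro switch

The source may hold more compounds than are shown below. What is called first, only, known or untested is meant among the compounds shown, and "the series" means these compounds.

Compound 1 `COc1ccccc1/C=C/C(=O)OC/C=C/c1cc(OC)c(OC)cc1OC`: 100%
Compound 2 `COc1cc(OC)c(OC)cc1/C=C/COC(=O)/C=C/c1ccccc1Cl`: 100%
Compound 3 `COc1ccc(/C=C/C(=O)OC/C=C/c2cc(OC)c(OC)cc2OC)cc1`: 100%

The three measured compounds share one core and differ only in the aryl group on the double-bonded chain carbon. In a functional assay on the whole organism (strain Kunming) with Mus musculus as the target, with a stated time of 0.5 h, at a dose of 100 mg/kg by the intraperitoneal route (on this read-out lower numbers stand for a stronger effect and higher numbers for a weaker effect at the one dose given), compound 1 gives 100%, compound 2 gives 100% and compound 3 gives 100%. The step of no change at the digits printed from compound 1 to compound 2 (within the scatter) follows the change (chloro in place of methoxy on an aromatic carbon). The two cores of compound 1 and compound 3 differ as 4-methoxyphenyl in place of 2-methoxyphenyl on a double-bonded chain carbon bound to a double-bonded chain carbon, and the step of no change at the digits printed from compound 1 to compound 3 (within the scatter) is accordingly flat, as is no change at the digits printed from compound 2 to compound 3 (within the scatter).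

Compound 4 `COc1cc(OC)c(OC)cc1/C=C/COC(=O)/C=C/c1ccc(Cl)cc1` is not yet measured. It differs from compound 3 by chloro in place of methoxy on an aromatic carbon, which is the same kind of change as that from compound 1 to compound 2; the difference is that the earlier change sits ortho to a large group, whereas here it sits para to a large group. Because no change at the digits printed from compound 1 to compound 2 (within the scatter) showed no movement, the step of no change at the digits printed from compound 3 to compound 4 (within the scatter) is expected to be small. Compound 4 is therefore estimated at 100%, with a range from 85% to 100%, resting on the flat step no change at the digits printed from compound 1 to compound 2 (within the scatter) and on compound 3 itself giving 100%.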

Compound 4, a percentage reported as activity, at one dose (the size of the read-out at that dose, not a potency): 100%
The estimate for compound 4 equals the measured number at the digits printed; the measured number falls inside the stated range.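

Chloro in place of methoxy on the core of compound 3 gives no change at the digits printed from compound 3 to compound 4 (within the scatter), and the other two new steps read the same way: no change at the digits printed from compound 2 to compound 4 (within the scatter) and no change at the digits printed from compound 1 to compound 4 (within the scatter). Set side by side, the two instances of this change agree in this assay: the same change on two cores in this assay, no change at the digits printed (within the scatter) from compound 1 to compound 2 and no change at the digits printed (within the scatter) from compound 3 to compound 4, 0 percentage points apart, within the scatter of two such steps. This shows that the change carried over between these two cores without moving the read-out, but with compound 4 at 100%, level with the other three compounds, it does not show how the change would behave on a core where the read-out moves away from this value, or at any other dose.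

Still open, from the compounds shown here alone, is whether any group on the aryl ring can shift the read-out at all, for instance an amine or a carboxylic acid in the place held here by chloro or methoxy. Equally open, going by these compounds, is what an amide in place of the ester, or a longer chain between the ester and the trimethoxyphenyl ring, would do.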